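Series notes: acetamidomethyl replacing trifluoromethyl on the aryl of compound 1

A few compounds are considered here, and "the series" means these few. Any claim that something is new, unique, unknown or untested is made for them only; others in the source may bear on it.

Measured compounds:
compound 1 `Cn1nc2c(=O)n(CC3(O)CCN(Cc4ccc(-c5ccco5)cc4Cl)CC3)cnc2c1-c1ccc(C(F)(F)F)cc1`, 530 nM
compound 2 `Cn1nc2c(=O)n(CC3(O)CCN(Cc4ccc(-c5ccoc5)cc4Cl)CC3)cnc2c1-c1ccc(CN)cc1`, 177 nM
compound 3 `Cn1nc2c(=O)n(CC3(O)CCN(Cc4ccc(-c5n[nH]c(=O)o5)cc4Cl)CC3)cnc2c1-c1ccc(CN)cc1`, 171 nM

In an assay on isolated protein for inhibition of ubiquitin carboxyl-terminal hydrolase 7 (Homo sapiens), with stated times of 30 min and 2 h (a higher number here means a weaker inhibitor, a lower number a stronger inhibitor), compound 1 gives the highest number of the three; compound 2 and compound 3 both give lower numbers, and both gaps lie beyond the scatter. For the measured compounds named here, compound 2 and compound 3 differ from compound 1 in two places at once, at the aromatic carbon carrying the trifluoromethyl and at the ring on the other end, so no single-point step to compound 1 exists. Going by the values given here, the one single-point step recorded, a 1.0-fold lower number from compound 2 to compound 3 (0.01 log units; within the scatter), concerns the far ring only and lies within the scatter, so it does not bear on the present change.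

Compound 4 `CC(=O)NCc1ccc(-c2c3ncn(CC4(O)CCN(Cc5ccc(-c6ccco6)cc5Cl)CC4)c(=O)c3nn2C)cc1` arises from compound 1 by acetamidomethyl in place of trifluoromethyl on an aromatic carbon. Only the joint comparison of compound 1 with compound 2 and compound 3 speaks for a lower number when the trifluoromethyl is exchanged; the change in compound 4 is not identical, so only a moderate step is expected. For compound 4 a value of 300 nM is estimated, between 130 nM and 700 nM. This estimate means a step of a 1.8-fold lower number from compound 1 to compound 4 (0.25 log units; within the scatter) in this assay.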

Compound 4, half-maximal inhibitory concentration: 46.1 nM
For compound 4 the middle estimate is 6.5-fold (0.81 log units) above the measured one; measured number outside the range, below it.
By their numbers in this assay, from the lowest: compound 4; then compounds 3 and 2 (each within the scatter of the next); then compound 1.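

In this assay the exchange on this aromatic carbon can now be read alone, with the rest of compound 1 unchanged: acetamidomethyl in place of trifluoromethyl gives an 11-fold lower number from compound 1 to compound 4 (1.06 log units; beyond the scatter), a large step. The earlier compounds shown here changed this substituent only together with the far ring, so they gave no separate reading of this position. No measurement at hand accounts for the step.

Which part of the acetamidomethyl group carries the step remains open; a nitrile, a carboxylic acid or a longer amide chain on the same aromatic carbon would help to separate the carbonyl, the amide hydrogen and the chain length. Also open, going by these compounds, is whether a step of this size would hold with a different far ring.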